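Moving chlorine from 3-chlorobenzyl to 2-chlorobenzyl

A few compounds are considered here, and "the series" means these few. Any claim that something is new, unique, unknown or untested is made for them only; others in the source may bear on it.

In a functional assay on MCF7 cells (Homo sapiens) for cytotoxicity, read by MTT assay, with a stated time of 24 h (a lower number here means a stronger inhibitor, a higher number a weaker inhibitor), compound 1 `O=C1/C(=C/c2ccccc2F)CN(Cc2cn(Cc3ccccc3F)nn2)C/C1=C\c1ccccc1F` gives 6000 nM. Compound 2 `O=C1/C(=C/c2ccccc2F)CN(Cc2cn(Cc3cccc(Cl)c3)nn2)C/C1=C\c1ccccc1F` gives 12000 nM and stands within the scatter of compound 1: the measured change is a 2.0-fold higher number from compound 1 to compound 2 (0.30 log units; within the scatter). Compound 3 `Cc1ccc(/C=C2\CN(C(=S)SCc3cn(Cc4ccccc4F)nn3)C/C(=C\c3ccc(C)cc3)C2=O)cc1` is reported only as a limit, > 100000 nM.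

Compound 4 `O=C1/C(=C/c2ccccc2F)CN(Cc2cn(Cc3ccccc3Cl)nn2)C/C1=C\c1ccccc1F` is not yet measured. Its difference from compound 2 is 2-chlorophenyl in place of 3-chlorophenyl on a saturated chain carbon bound to an aromatic nitrogen. Going by the values given here, one measured step bears on this place, a 2.0-fold higher number from compound 1 to compound 2 (0.30 log units; within the scatter), with 3-chlorophenyl in place of 2-fluorophenyl. Among the compounds with values here, compound 3 differs in more than one place and offers no comparable step. Given the size of that single step, no change beyond the scatter is expected in this assay.

The estimated change is a 1.3-fold lower number from compound 2 to compound 4 (0.12 log units; within the scatter). Compound 4 is expected at 9000 nM, with an estimated range from 4000 nM to 20000 nM.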

Compound 4, half-maximal inhibitory concentration: 10000 nM
The estimate for compound 4 lay 1.1-fold (0.05 log units) below the measured number, and the stated range covers the measured number.
By their numbers in this assay, from the lowest: compounds 1, 4 and 2 (each within the scatter of the next). At a limit, above all of these: compound 3.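

In this assay the change from 3-chlorophenyl to 2-chlorophenyl gives a 1.2-fold lower number from compound 2 to compound 4 (0.08 log units; within the scatter) and so the placement of the chlorine on this ring does not separate the two compounds. The exchange of halogen, chloro in place of fluoro on an aromatic carbon, gives a 1.7-fold higher number from compound 1 to compound 4 (0.22 log units; within the scatter) and with it compound 1, compound 2 and compound 4 all stand within the scatter of one another, a reading confined to these three compounds. Going by these compounds alone, compound 3 differs from them in more than one place and its value is a limit, so no step to it can be read.

As far as these compounds go, whether an amine or a carboxylic acid on this ring, or a longer chain at this place, would move the number beyond the scatter remains open. Nothing measured here gives a cause for these small steps.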